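The source may report more compounds than this note shows. Statements on the series, on what has been measured and on what is new or still open speak of the compounds shown alone.

Compound 1 is `O=C(Nc1cccc(OCc2ccc(-c3ccccc3)cc2)c1)C1CCNCC1` and in a functional assay on a cell-free system (Platelet, plasma, Homo sapiens) for inhibition (on this read-out higher numbers stand for weaker inhibition and lower numbers for stronger inhibition), compound 1 gives 111000 nM.
Compound 2 is `O=C(Nc1cccc(OCc2ccc(-c3ccccc3F)cc2)c1)C1CCNCC1` and in this assay compound 2 gives 62700 nM.
Compound 3 is `O=C(Nc1cccc(OCc2ccc(-c3cc(F)ccc3F)cc2)c1)C1CCNCC1` and in this assay compound 3 gives "not determined" (no result reported).

In this assay compound 1 gives 111000 nM and compound 2 gives 62700 nM. Compound 3 has no number in this assay and so cannot be placed against either of them. Compound 4 is `O=C(Nc1cccc(OCc2ccc(-c3ccc(C(F)(F)F)cc3)cc2)c1)C1CCNCC1`; relative to compound 3 the change is 4-(trifluoromethyl)phenyl in place of 2,5-difluorophenyl on an aromatic carbon. Within the data shown here, the only measured step, a 1.8-fold lower number from compound 1 to compound 2 (0.25 log units; within the scatter), concerns fluoro in place of hydrogen on an aromatic carbon, not the exchange of one substituted phenyl for another, so it gives no direction for the present change. With compounds 1 and 2 within the scatter of each other, no step beyond the scatter is expected for compound 4 in this assay. Compound 4 is therefore estimated at 75000 nM in this assay, with a range of 25000 nM to 220000 nM.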

Compound 4, half-maximal inhibitory concentration: 65700 nM
Estimate against measurement, compound 4: 1.1-fold (0.06 log units) above; measured number inside the range.
By their numbers in this assay, from the lowest: compounds 2, 4 and 1 (each within the scatter of the next).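

In this assay, trifluoromethyl in place of hydrogen, para to a large group, gives a 1.7-fold lower number from compound 1 to compound 4 (0.23 log units; within the scatter), and 4-(trifluoromethyl)phenyl in place of 2-fluorophenyl gives a 1.0-fold higher number from compound 2 to compound 4 (0.02 log units; within the scatter). This position therefore accepts a para trifluoromethyl group as well as the 2-fluorophenyl group with no step beyond the scatter, so neither fluorinated phenyl separates from the plain phenyl of compound 1. Nothing at hand accounts for this flat result. On these data alone, whether an amine, a carboxylic acid or a longer chain at this position would give a step beyond the scatter remains open.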